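The source may hold more compounds than are shown below. What is called first, only, known or untested is meant among the compounds shown, and "the series" means these compounds.

Measured in a functional assay on HT-29 cells (Homo sapiens) for inhibition; a higher number here means a weaker inhibitor, a lower number a stronger inhibitor:

- compound 1 `COc1cc(/C=C\c2ccc3ccccc3c2)ccc1F`: 450 nM
- compound 2 `FC(F)(F)c1ccc(/C=C/c2ccc3ccccc3c2)cc1`: > 5000 nM, a limit
- compound 3 `FC(F)(F)c1ccc(/C=C\c2ccc3ccccc3c2)cc1`: > 5000 nM, a limit

Compound 3 has no exact number in this assay. Its reading of > 5000 nM is a limit. It therefore sits at the limit of > 5000 nM in this assay, at which 2 of the 3 values shown sit.

Compound 4 `CN(C)c1ccc(/C=C\c2ccc3ccccc3c2)cc1` changes one group of compound 3: dimethylamino in place of trifluoromethyl on an aromatic carbon. Dimethylamino replaces trifluoromethyl on an aromatic carbon, para to a large group.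

Within the data shown here, the only measured step between two close relatives is a step that the two limits leave unreadable from compound 2 to compound 3. It concerns (the fact that compounds 2 and 3 differ only in the configuration as drawn), not this group, and offers no size to carry over. Among the measured compounds shown here, the one exact reading is that compound 1 gives 450 nM, which shows that a number can be obtained in this assay, though compound 1 carries different groups.

A modest gain in strength is therefore expected, with low confidence, and compound 4 may still return only a limit. The expected change is an at least 2.5-fold lower number from compound 3 to compound 4 (0.39 log units; beyond the scatter). Compound 4 is estimated at 2000 nM, with an expected range from 300 nM to 10000 nM.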

Compound 4, half-maximal inhibitory concentration: 3660 nM
Beside the measured number, compound 4's estimate is 1.8-fold (0.26 log units) below it; the range from low to high includes it.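

At this place, on an aromatic carbon para to a large group, dimethylamino gives an exact reading where trifluoromethyl did not: compound 4 gives 3660 nM in this assay and so sits within the range this assay can put a number on. Measured against trifluoromethyl, the change is an at least 1.3-fold lower number from compound 3 to compound 4 (0.13 log units; that floor lies within the scatter) and so a real gain in strength is not established. The true size of the step stays hidden, and the reading for compound 3 is where it stops: the limit of > 5000 nM in this assay, at which 2 of the 4 values shown sit.

From the compounds shown here alone, the step between compound 2 and compound 3 cannot be read, so it remains unknown whether the configuration of the double bond matters in this assay. Also open, going by these compounds, is how a carboxylic acid or a primary amine would read at this same place.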